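Fluoro to trifluoromethyl on an aromatic ring

This account rests on a few compounds, and the source may have more. Where it says the series, first, only, none or still open, it means among the compounds named here.

Going by the values given here, in an ADME assay on MT4 cells (Homo sapiens) for cytotoxicity, read by MTT assay, with a stated time of 5 days (on this read-out lower numbers stand for higher toxicity in this test and higher numbers for lower toxicity in this test), compound 2 `COc1cc2nc([S+]([O-])CC(=O)Nc3cccc(F)c3)nc(Nc3c(Cl)cc(/C=C/C#N)cc3Cl)c2cc1OC` gives 9550 nM, the lower of the two numbers so far, while compound 1 `COc1cc2nc([S+]([O-])CC(=O)Nc3ccc([N+](=O)[O-])cc3)nc(Nc3c(Cl)cc(/C=C/C#N)cc3Cl)c2cc1OC` gives 92800 nM. Compound 3 `COc1cc2nc([S+]([O-])CC(=O)Nc3cccc(C(F)(F)F)c3)nc(Nc3c(Cl)cc(/C=C/C#N)cc3Cl)c2cc1OC` has trifluoromethyl in place of fluoro on an aromatic carbon. Among the compounds with values here, the only measured step, a 9.7-fold lower number from compound 1 to compound 2 (0.99 log units; beyond the scatter), lies beyond the scatter and also concerned this ring, but it exchanged other groups, so it gives no direction for this swap. The expected step is a 1.1-fold lower number from compound 2 to compound 3 (0.03 log units; within the scatter), no larger than the scatter in this assay. For compound 3 the estimate is 9000 nM, with an expected range of 3500 nM to 28000 nM.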

Compound 3, half-maximal cytotoxic concentration: 21800 nM
For compound 3 the middle estimate is 2.4-fold (0.38 log units) below the measured one, within the range that was stated.
By their numbers in this assay, from the lowest: compound 2; then compound 3; then compound 1.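

In this assay, trifluoromethyl in place of fluoro on this aromatic carbon raises the number (a 2.3-fold higher number from compound 2 to compound 3 (0.36 log units; beyond the scatter)), so the larger group gives lower toxicity in this test. Compound 3 therefore sits between the other two, and the change from the 4-nitrophenyl group still leaves a clear gap (a 4.3-fold lower number from compound 1 to compound 3 (0.63 log units; beyond the scatter)). Nothing available explains why this swap moves the number. Still open, from the compounds shown here alone, is whether a methoxy group or an amine on the same ring carbon would raise the number further, and whether trifluoromethyl would act the same way on another ring carbon.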